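The source may hold more compounds than are shown below. What is called first, only, known or untested is meant among the compounds shown, and "the series" means these compounds.

Within the data shown here, in a functional assay (plasma) with Oryctolagus cuniculus as the target (a lower number here means a stronger inhibitor, a higher number a weaker inhibitor), compound 1 `Cc1nc2cnccc2n1CC1CCN(C(=O)CC(O)(c2ccccc2)c2ccccc2)CC1` gives 640 nM and compound 2 `Cc1nc2cnccc2n1CC1CCN(C(=O)CC(C)(O)c2ccccc2)CC1` gives 6.9 nM as the lower of the two numbers so far. Compound 3 `Cc1nc2cnccc2n1CC1CCN(C(=O)CC(O)(c2ccccc2)C(F)(F)F)CC1` differs from compound 2 in one place, with trifluoromethyl in place of methyl on a saturated chain carbon bound to an aromatic carbon, an oxygen on a saturated carbon and a saturated chain carbon. Among the measured compounds shown here, the only measured step at this place (a 93-fold lower number from compound 1 to compound 2 (1.97 log units; beyond the scatter)) was large, but it exchanged phenyl and methyl, not trifluoromethyl, so it shows that this place can matter without fixing a size. A modest move to a higher number in this assay is expected (a 2.9-fold higher number from compound 2 to compound 3 (0.46 log units; beyond the scatter)). For compound 3 the estimated value is 20 nM with an expected range from 4 nM to 100 nM as the likely span.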

Compound 3, half-maximal inhibitory concentration: 36 nM
Compound 3: the middle estimate sits 1.8-fold (0.26 log units) below what was measured; low and high end bracket the measured number.
By their numbers in this assay, from the lowest: compound 2; then compound 3; then compound 1.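

In this assay the step of a 5.2-fold higher number from compound 2 to compound 3 (0.72 log units; beyond the scatter) is modest, whereas the step of an 18-fold lower number from compound 1 to compound 3 (1.25 log units; beyond the scatter) is large. This position therefore does more than separate methyl from phenyl: trifluoromethyl gives an intermediate result, and the order from lowest number to highest is methyl, trifluoromethyl, phenyl. Among these three compounds, replacing methyl with trifluoromethyl costs far less than having phenyl at this carbon. As far as these compounds go, how a simple hydrogen, an ethyl group or a longer chain would behave here remains open. No data shown explain why the three groups rank this way.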